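Swapping the aryl group on a piperazine-linked oxazole amide

This account rests on a few compounds, and the source may have more. Where it says the series, first, only, none or still open, it means among the compounds named here.

Measured so far:
compound 1, `CC(=O)c1ccc(N2CCN(C(=O)c3oc(C)nc3-c3ccccc3)CC2)cc1`, in a functional assay on HL-60 cells (Homo sapiens) for inhibition, read by MTT assay, with a stated time of 72 h; a lower number here means a stronger inhibitor, a higher number a weaker inhibitor: "not active" (no number reported)
compound 2, `Cc1nc(-c2ccccc2)c(C(=O)N2CCN(c3ccccc3C(F)(F)F)CC2)o1`, in this assay: 120 nM

Among the measured compounds shown here, compound 2 stands as the only compound with a number in this assay; compound 1 gave no number there. Compound 3, `Cc1nc(-c2ccccc2)c(C(=O)N2CCN(c3ccc(C)c(C)c3)CC2)o1`, differs from compound 2 in one place: 3,4-dimethylphenyl in place of 2-(trifluoromethyl)phenyl on an amine nitrogen in a ring. For the measured compounds named here, no measured pair shares this change, so the size of the step is uncertain. Compound 1 shows that a different aryl group on this ring nitrogen can remove activity, so a weakening beyond the scatter is expected for compound 3, estimated as a 3.8-fold higher number from compound 2 to compound 3 (0.57 log units; beyond the scatter). Compound 3 is expected to give about 450 nM, in the range 110 nM to 3000 nM.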

Compound 3, half-maximal inhibitory concentration: 43 nM
The estimate for compound 3 lay 10-fold (1.02 log units) above the measured number; the whole stated range lies above it.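

In this assay, the aryl group on this ring nitrogen can be exchanged with a gain in activity: 3,4-dimethylphenyl in place of 2-(trifluoromethyl)phenyl gives a 2.8-fold lower number from compound 2 to compound 3 (0.45 log units; beyond the scatter). The trifluoromethyl group is therefore not required for activity, and of the three aryl groups shown, only the acetyl-bearing one in compound 1 gave no number. No available measurement explains this gain. From the compounds shown here alone, whether a single methyl group would serve as well remains open, as does the effect of an amine or a carboxylic acid on this aryl ring.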